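The source may hold more compounds than are shown below. What is called first, only, known or untested is meant among the compounds shown, and "the series" means these compounds.

Compound 1 `CCCCNc1nc(SC)nc2ncccc12`: 270 nM
Compound 2 `CCOCCNc1nc(SC)nc2ncccc12`: 7590 nM
Compound 3 `CSc1nc(Nc2ccccc2)c2cccnc2n1`: 15900 nM

In a functional assay (Nicotiana tabacum) (on this read-out lower numbers stand for stronger inhibition and higher numbers for weaker inhibition), compound 3 has the highest number of the three, 15900 nM, which makes it the weakest inhibitor measured so far. Compound 4 `COc1ccc(Nc2nc(SC)nc3ncccc23)cc1` is the same structure with methoxy in place of hydrogen on an aromatic carbon, para to a large group (methoxy in place of hydrogen on an aromatic carbon). Within the data shown here, no measured step changes a group on that ring, so the evidence is indirect. Two steps do alter the same nitrogen: the large 59-fold higher number from compound 1 to compound 3 (1.77 log units; beyond the scatter) and the modest 2.1-fold higher number from compound 2 to compound 3 (0.32 log units; beyond the scatter). Both swap the whole group, however, rather than add to it. The closest parallel is the large 28-fold higher number from compound 1 to compound 2 (1.45 log units; beyond the scatter), where ethoxy replaced ethyl. That change sits on a saturated chain rather than an aromatic ring, so it offers only a weak hint of a higher number. No step beyond the scatter is therefore expected, with a slight lean upward. The expected step is a 1.3-fold higher number from compound 3 to compound 4 (0.10 log units; within the scatter). For compound 4 the estimated value is 20000 nM, with an expected range from 5000 nM to 80000 nM.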

Compound 4, half-maximal inhibitory concentration: 9420 nM
Compound 4: the middle estimate sits 2.1-fold (0.33 log units) above what was measured; measured number inside the range.
By their numbers in this assay, from the lowest: compound 1; then compounds 2, 4 and 3 (each within the scatter of the next, the first and the last beyond it).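

In this assay, methoxy in place of hydrogen on an aromatic carbon, para to a large group, gives a 1.7-fold lower number from compound 3 to compound 4 (0.23 log units; within the scatter) and so stays within the usual scatter. Among these compounds, this is the first sign that a group of 2 heavy atoms can stand at this position on the phenyl ring without a clear change in the read-out, and the step is small beside a 59-fold higher number from compound 1 to compound 3 (1.77 log units; beyond the scatter) for the swap of butyl to phenyl. No measurement at hand gives a reason for this result.

Going by these compounds, whether a larger or differently built group at this same carbon, such as an amine, a carboxylic acid or a longer chain, would move the number beyond the scatter remains open. On these data alone, it is also open whether methoxy would behave the same way on another carbon of that ring.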